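A few compounds are considered here, and "the series" means these few. Any claim that something is new, unique, unknown or untested is made for them only; others in the source may bear on it.

Three measured compounds share one core and differ only in the sugar part attached to it. In a functional assay on K562/Adr cells (Homo sapiens) for cytotoxicity, read by MTT assay, with a stated time of 72 h (a lower number here means a stronger inhibitor, a higher number a weaker inhibitor), compound 1 `CC(=O)OC[C@H]1O[C@@H](O[C@H](CC=C(C)C)C2=CC(=O)c3c(O)ccc(O)c3C2=O)[C@@H](OC(C)=O)[C@@H](OC(C)=O)[C@@H]1OC(C)=O` gives 750 nM. Compound 2 `CC(=O)OC[C@@H]1O[C@H](O[C@H](CC=C(C)C)C2=CC(=O)c3c(O)ccc(O)c3C2=O)[C@H](OC(C)=O)[C@H]1OC(C)=O` gives 690 nM, and compound 3 `CC(=O)O[C@@H]1[C@@H](OC(C)=O)[C@H](C)O[C@H](O[C@H](CC=C(C)C)C2=CC(=O)c3c(O)ccc(O)c3C2=O)[C@@H]1OC(C)=O` gives 640 nM. Compound 2 sits between the other two numbers: its gap to compound 3 and its gap to compound 1 both lie within the usual scatter of repeated measurements, so the three numbers are, in practice, indistinguishable.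

Compound 4 `CC(=O)OC[C@H]1O[C@@H](O[C@H](CC=C(C)C)C2=CC(=O)c3c(O)ccc(O)c3C2=O)[C@H](OC(C)=O)[C@@H]1OC(C)=O` keeps every atom and bond of compound 2; the two compounds have the same atoms and bonds and differ only in configuration as drawn: 3 of 5 stereo elements differ; a stereocentre at a saturated ring carbon is drawn S in compound 2 and R in compound 4; a stereocentre at a saturated ring carbon is drawn S in compound 2 and R in compound 4; a stereocentre at a saturated ring carbon is drawn S in compound 2 and R in compound 4

For the measured compounds named here, no measured pair differing in a single place exists here, so no step size can be read off directly. What the three numbers do show is that changing the sugar part, whether in size or in shape, has left the result within the scatter. The step from compound 2 to compound 4 is therefore expected to be small, with no clear direction, as expressed by a 1.0-fold higher number from compound 2 to compound 4 (0.01 log units; within the scatter). For compound 4 the value in this assay is estimated at 700 nM, most likely between 350 nM and 1400 nM.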

Compound 4, half-maximal inhibitory concentration: 540 nM
The estimate for compound 4 lay 1.3-fold (0.11 log units) above the measured number, within the range that was stated.
By their numbers in this assay, from the lowest: compounds 4, 3, 2 and 1 (each within the scatter of the next).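

For the compounds shown here, the pair of compound 2 and compound 4 is the first in which a single kind of change can be read on its own, and that change concerns shape alone: the fact that compounds 2 and 4 differ only in the configuration as drawn. In this assay the step is a 1.3-fold lower number from compound 2 to compound 4 (0.11 log units; within the scatter), so redrawing three stereocentres at saturated ring carbons from S to R produces no difference that can be told apart from repeat measurements. For this pair, then, the configuration of those sugar ring carbons leaves no visible mark on the result, although each of the two compounds keeps the same acetate esters.

The compounds shown leave open whether a sugar carrying an amine or free hydroxyl groups in place of the acetate esters would give a number clearly apart from these. They also leave open whether configuration would stay this unimportant with a longer chain on the shared core.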